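From 3-Nitrophenyl to 3-Bromo-4-hydroxyphenyl: Expected Potency

The source may hold more compounds than are shown below. What is called first, only, known or untested is meant among the compounds shown, and "the series" means these compounds.

Measured so far:
- compound 1, `COc1ccc(C(=O)/C=C/c2cccc([N+](=O)[O-])c2)c2c1C=CC(C)(C)O2`: 4260 nM
- compound 2, `COc1ccc(C(=O)/C=C/c2ccc(OC)c(OC)c2OC)c2c1C=CC(C)(C)O2`: > 10000 nM

Among the measured compounds shown here, in a functional assay on HT-29 cells (Homo sapiens) for antiproliferative activity, read by MTT assay, with a stated time of 24 h (on this read-out higher numbers stand for weaker inhibition and lower numbers for stronger inhibition), compound 1 gives 4260 nM and is the only compound with a measured number. For compound 2 this assay reports only a limit, > 10000 nM, so its two values show that compound 1 inhibits growth while compound 2 does not reach a measurable value; of the two values shown, one sits at the limit of > 10000 nM in this assay, at which 1 of the 2 values shown sits.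

Compound 3, `COc1ccc(C(=O)/C=C/c2ccc(O)c(Br)c2)c2c1C=CC(C)(C)O2`, is not yet measured. It differs from compound 1 in one place: 3-bromo-4-hydroxyphenyl in place of 3-nitrophenyl on a double-bonded chain carbon bound to a double-bonded chain carbon. For the measured compounds named here, no comparison between measured compounds covers a change of this kind, so there is no measured step to lean on. The expected step from compound 1 to compound 3, a 1.2-fold lower number from compound 1 to compound 3 (0.09 log units; within the scatter), is small and within the usual scatter, with no clear direction. Compound 3 is therefore estimated at 3500 nM, with a range from 1200 nM to 10000 nM.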

Compound 3, half-maximal inhibitory concentration: > 10000 nM
Compound 3 gave a limit, no number; the forecaster's own chance of this, stated with the estimate: 20%; middle value at least 2.8-fold (0.45 log units) away from the limit.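

In this assay, the ring carried at this place is not a neutral choice: 3-bromo-4-hydroxyphenyl in place of 3-nitrophenyl gives an at least 2.3-fold higher number from compound 1 to compound 3 (0.37 log units; beyond the scatter). This is the first measured step at this place, and it shows that changing the ring here can move the read-out beyond the scatter, leaving 3-nitrophenyl as the only group shown with a number. As far as these compounds go, compound 3 joins compound 2 at a limit rather than a number, so the true size of the step stays unknown: the limit of > 10000 nM in this assay, at which 2 of the 3 values shown sit.

The bromine and the hydroxyl enter together, so the compounds shown cannot say which of them matters, or whether losing the nitro group alone is enough. Also open, from the compounds shown here alone, is whether a ring carrying an amine or a carboxylic acid would give a number at all.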